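The source may hold more compounds than are shown below. What is called first, only, known or untested is meant among the compounds shown, and "the series" means these compounds.

compound 1 `C=C(c1ccc(OC)cc1NC(=O)CO)c1ccc(OC)c2c1OC(C)(C)C=C2` gives 40 nM
compound 2 `C=C(c1ccc(OC)cc1NC(=O)CO)c1ccc(OC)c2c1C=CC(C)(C)O2` gives 100 nM

Both values come from a functional assay on HeLa cells (Homo sapiens) for antiproliferative activity, read by MTT assay, with a stated time of 48 h; a lower number here means a stronger inhibitor, a higher number a weaker inhibitor. Compound 1 has the lower number of the two, and its gap to compound 2 lies beyond the usual scatter, so compound 1 is the stronger inhibitor of this pair.

Compound 3 `C=C(c1ccc(OC)cc1NC(=O)CNC)c1ccc(OC)c2c1OC(C)(C)C=C2` keeps the core of compound 1 but has methylamino in place of hydroxy on a saturated chain carbon bound to a carbonyl carbon. Within the data shown here, no measured pair here shows this change, so the expectation rests only on compound 1 at 40 nM and remains loose. A small move toward a higher number is expected in this assay, an estimated 1.8-fold higher number from compound 1 to compound 3 (0.24 log units; within the scatter) that may stay within the scatter. Compound 3 is expected at 70 nM (estimated range 20 nM to 250 nM).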

Compound 3, half-maximal inhibitory concentration: 310 nM
For compound 3 the middle estimate is 4.4-fold (0.65 log units) below the measured one; the whole stated range lies below it.
By their numbers in this assay, from the lowest: compound 1; then compound 2; then compound 3.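

On the saturated chain carbon bound to a carbonyl carbon, putting methylamino in place of hydroxy in this assay gives a 7.8-fold higher number from compound 1 to compound 3 (0.89 log units; beyond the scatter) and so makes compound 3 the weaker inhibitor. This shows that the position is sensitive to which group it carries, which compounds 1 and 2 could not show, as both have hydroxy there. Hydroxy and methylamino have the same counts of hydrogen-bond donors and acceptors, so matching those counts did not preserve the activity here, and no further data bear on this result.

From the compounds shown here alone, it remains open whether the loss follows the nitrogen or the added methyl, which a plain amine or a methoxy group on the same carbon could help separate. Going by these compounds, it is also open whether the same change would have a similar effect on the core of compound 2.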